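The compounds below may be only part of what the source reports. "The series", "measured", "known", "first", "only" and "open" are said of these compounds alone.

Compound 2 `CCCCCCCCCCc1ccc(-c2noc([C@@H]3CC[C@H](N)C3)n2)cc1` stands lowest of the two compounds measured in an assay on HeLa cells for inhibition of sphingosine-1-phosphate transporter SPNS2 (Mus musculus), read by LC-MS, tested at 2 uM; on this read-out higher numbers stand for more inhibition at the one concentration tested (going by the name of the read-out) and lower numbers for less inhibition: compound 2 gives 38%, while compound 1 `CCCCCCCCCCc1ccc(-c2noc(CN)n2)cc1` gives 62%. The step of a number 24 percentage points lower from compound 1 to compound 2 (beyond the scatter) went with 3-aminocyclopentyl in place of aminomethyl. Compound 3 `CCCCCCCCCCc1ccc(-c2noc([C@@H]3CCC[C@@H](N)C3)n2)cc1` differs from compound 2 by 3-aminocyclohexyl in place of 3-aminocyclopentyl on an aromatic carbon. Among the compounds with values here, no measured step compares a five-membered ring with a six-membered one, so only that single step bears on it, and only loosely. The expected step is a number 2 percentage points higher from compound 2 to compound 3 (within the scatter), within the scatter. Compound 3 is therefore estimated at 40%, with a range from 15% to 65%.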

Compound 3, a percentage reported as inhibition, at one concentration (the size of the read-out at that concentration, not a potency): 13%
Compound 3: middle estimate off by 27 percentage points, on the high side; measured number outside the range, below it.
By their numbers in this assay, from the lowest: compound 3; then compound 2; then compound 1.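

In this assay, the six-membered ring of 3-aminocyclohexyl does not match the five-membered ring of 3-aminocyclopentyl at this position, with a number 25 percentage points lower from compound 2 to compound 3 (beyond the scatter) in this single pair. Against aminomethyl the change is larger, with a number 49 percentage points lower from compound 1 to compound 3 (beyond the scatter), so across these three compounds the number falls from aminomethyl through 3-aminocyclopentyl to 3-aminocyclohexyl, and none goes against that order. Nothing given here accounts for this fall. From the compounds shown here alone, whether a 2-aminoethyl or 4-aminocyclohexyl group would fit the same order remains open. So does how the other stereoisomers of 3-aminocyclohexyl would compare.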